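The source may report more compounds than this note shows. Statements on the series, on what has been measured and on what is new or still open speak of the compounds shown alone.

Compound 1 `COc1ccc(CSc2nc(Cc3ccc(Br)cc3)c(C)c(=O)[nH]2)cc1`, compound 2 `CCc1c(Cc2ccccc2Br)nc(SCc2ccc(OC)cc2)[nH]c1=O`, compound 3 `CCc1c(Cc2cccc(Br)c2)nc(SCc2ccc(OC)cc2)[nH]c1=O`.

In an ADME assay on MT4 cells (Homo sapiens) for cytotoxicity, read by MTT assay (on this read-out higher numbers stand for lower toxicity in this test and lower numbers for higher toxicity in this test), compound 1 reaches only the limit > 290000 nM, a limit of the test rather than a number. Compound 2 gives 165000 nM. Compound 3 gives 201000 nM. Of the three values, two are numbers and one is a limit; compound 3 and compound 2 lie within the scatter of each other, as the step of a 1.2-fold higher number from compound 2 to compound 3 (0.09 log units; within the scatter) shows. Compound 4 `CCc1c(Cc2ccc(Br)cc2)nc(SCc2ccc(OC)cc2)[nH]c1=O` differs from compound 3 by 4-bromophenyl in place of 3-bromophenyl on a saturated chain carbon bound to an aromatic carbon. Within the data shown here, the single measured step that bears on shifting the bromine around the ring was within the scatter, so no change beyond the scatter is expected here either. Compound 4 is therefore expected at 230000 nM, from 120000 nM to 450000 nM, an estimated step of a 1.1-fold higher number from compound 3 to compound 4 (0.06 log units; within the scatter).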

Compound 4, half-maximal cytotoxic concentration: > 281000 nM
Compound 4: a limit, no number (the forecaster's own chance of this, stated with the estimate: 35%); at least 1.2-fold (0.08 log units) between middle value and limit.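

With the 4-bromophenyl group, compound 4 ends at a limit of the test rather than a number: the limit of > 281000 nM in this assay, at which 1 of the 4 values shown sits. This gives an at least 1.3-fold higher number from compound 3 to compound 4 (0.14 log units; that floor lies within the scatter) and an at least 1.7-fold higher number from compound 2 to compound 4 (0.23 log units; that floor lies within the scatter), so moving the bromine around the ring has still shown no step beyond the scatter, although the limit leaves the true size unknown. The step involving compound 1 cannot be read.

Going by these compounds, what remains open is whether a true number for compound 4 would stand clear of the scatter. Also open, on these data alone, is how an amine or a carboxylic acid in place of the bromine would read in this assay.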